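The source may hold more compounds than are shown below. What is called first, only, known or untested is meant among the compounds shown, and "the series" means these compounds.

Measured compounds:
compound 1 `COc1cc(-c2nnc3n2NC(c2ccco2)C(C(=O)c2ccc(F)c(F)c2)S3)cc(OC)c1OC` — 36000 nM
compound 2 `COc1cc(-c2nnc3n2NC(c2ccco2)C(C(=O)c2cccc(Br)c2)S3)cc(OC)c1OC` — 63900 nM
compound 3 `COc1cc(-c2nnc3n2NC(c2cccs2)C(C(=O)c2ccc(Cl)cc2)S3)cc(OC)c1OC` — 32500 nM

Three compounds sharing a common core were tested in a functional assay on PC-3 cells (Homo sapiens) for cytotoxicity, read by MTT assay, with a stated time of 48 h; on this read-out higher numbers stand for weaker inhibition and lower numbers for stronger inhibition. Compound 1 gives 36000 nM, compound 2 gives 63900 nM and compound 3 gives 32500 nM. Compound 2 shows the highest of the three numbers, but its gaps to compound 1 and to compound 3 both lie within the usual scatter, so no order among them can be claimed.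

The unmeasured compound 4 `COc1cc(-c2nnc3n2NC(c2ccco2)C(C(=O)c2ccc(-c4ccccc4)cc2)S3)cc(OC)c1OC` derives from compound 2 by one change: 4-phenylphenyl in place of 3-bromophenyl on a carbonyl carbon. Among the measured compounds shown here, the only measured step at this same position is a 1.8-fold higher number from compound 1 to compound 2 (0.25 log units; within the scatter), which is within the scatter. Compound 3 also carries a different group on the carbonyl carbon, yet it differs from compound 2 in a second place as well, so only its value can be compared. Nothing measured here points to a shift beyond the scatter, and the step from compound 2 to compound 4 in this assay is therefore expected to be small, a 1.3-fold lower number from compound 2 to compound 4 (0.11 log units; within the scatter). Compound 4 is estimated at 50000 nM in this assay, with a range from 15000 nM to 150000 nM.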

Compound 4, half-maximal inhibitory concentration: 45900 nM
Compound 4: the middle estimate sits 1.1-fold (0.04 log units) above what was measured, and the stated range covers the measured number.
By their numbers in this assay, from the lowest: compounds 3, 1, 4 and 2 (each within the scatter of the next).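

In this assay, 4-phenylphenyl in place of 3-bromophenyl on the carbonyl carbon gives a 1.4-fold lower number from compound 2 to compound 4 (0.14 log units; within the scatter) and 4-phenylphenyl in place of 3,4-difluorophenyl gives a 1.3-fold higher number from compound 1 to compound 4 (0.11 log units; within the scatter) at the same position. Among the compounds shown here, the change adds a second six-membered aromatic ring of carbon only and removes the bromine, yet all three groups now compared at this position on the shared core stay within the scatter of one another, where the earlier compounds offered a single step. The data offer no measured explanation for this lack of separation.

On these data alone, all three groups are aromatic rings of carbon only, so the position remains untested with other kinds of group. As far as these compounds go, whether an amine, a carboxylic acid or a longer alkyl chain on the carbonyl carbon would shift the number beyond the scatter stays open.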